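This account rests on a few compounds, and the source may have more. Where it says the series, first, only, none or still open, it means among the compounds named here.

Of the compounds shown here, three built on one shared core have been tested in a functional assay on MGC-803 cells (Homo sapiens) for antiproliferative activity, read by MTT assay, with a stated time of 72 h; on this read-out higher numbers stand for weaker inhibition and lower numbers for stronger inhibition. Compound 1 `CCCSc1nc(Cl)c2c(n1)N(Cc1ccccc1)C(C(=O)N1CCN(C(=O)OC(C)(C)C)CC1)N2` gives 32000 nM in this assay. Compound 2 `CCCSc1nc(Cl)c2c(n1)N(Cc1cccs1)C(C(=O)N1CCN(C)CC1)N2` gives 62300 nM in this assay. For compound 3 `CCCSc1nc(Cl)c2c(n1)N(Cc1ccccc1)C(C(=O)NCCNC(=O)OC(C)(C)C)N2` the result in this assay is only a limit, > 64000 nM, which is the limit of > 64000 nM in this assay, at which 1 of the 3 values shown sits. Compound 3 therefore stands at the edge of the measured window, with no exact number of its own. Compound 4 `CCCSc1nc(Cl)c2c(n1)N(Cc1ccccc1)C(C(=O)NCCCc1ccccc1)N2` differs from compound 3 by benzyl in place of (tert-butoxycarbonyl)amino on a saturated chain carbon, two bonds along the chain from an amide-type nitrogen. For the measured compounds named here, no measured pair shows this change, so its size and direction cannot be read from the data. Compound 4 is expected to remain weak in this assay, at an estimated 40000 nM with a range from 10000 nM to 100000 nM, and the expected step of an at least 1.6-fold lower number from compound 3 to compound 4 (0.20 log units; that floor lies within the scatter) is itself uncertain.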

Compound 4, half-maximal inhibitory concentration: 16900 nM
For compound 4 the middle estimate is 2.4-fold (0.37 log units) above the measured one; the range from low to high includes it.
By their numbers in this assay, from the lowest: compounds 4, 1 and 2 (each within the scatter of the next, the first and the last beyond it). At a limit, above all of these: compound 3.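

In this assay, benzyl in place of (tert-butoxycarbonyl)amino on a saturated chain carbon, two bonds along the chain from an amide-type nitrogen, gives an at least 3.7-fold lower number from compound 3 to compound 4 (0.57 log units; beyond the scatter). This is the first readable step among these compounds, and it shows that the group at this place on the chain can move the number. The result for compound 3 is only a limit: the limit of > 64000 nM in this assay, at which 1 of the 4 values shown sits.

As far as these compounds go, it remains open whether the step comes from gaining benzyl or from losing (tert-butoxycarbonyl)amino. A free amine, a carboxylic acid or a longer chain at this place could help separate the two.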